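A few compounds are considered here, and "the series" means these few. Any claim that something is new, unique, unknown or untested is made for them only; others in the source may bear on it.

Measured so far in a functional assay on MCF7 cells (Homo sapiens) for cytotoxicity, read by neutral red uptake, with a stated time of 3 days; a lower number here means a stronger inhibitor, a higher number a weaker inhibitor:
Compound 1 `Cc1c(F)c(N)c2c(=O)cc(-c3ccc(N)c(F)c3)oc2c1F` gives 13 nM in this assay.
Compound 2 `Nc1ccc(-c2cc(=O)c3c(N)c(F)c(N)c(F)c3o2)cc1F` gives 7.7 nM in this assay.
Compound 3 `CCOC(=O)c1c(F)c(N)c2c(=O)cc(-c3ccc(N)c(F)c3)oc2c1F` gives 1400 nM in this assay.

Compound 3 stands highest of the three numbers in this assay. The two steps that lead into it are both large: a 110-fold higher number from compound 1 to compound 3 (2.03 log units; beyond the scatter) and a 180-fold higher number from compound 2 to compound 3 (2.26 log units; beyond the scatter). Going by the values given here, by contrast a 1.7-fold lower number from compound 1 to compound 2 (0.23 log units; within the scatter), so methyl and amino on that carbon sit close together, and ethoxycarbonyl is the single feature that sets compound 3 apart.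

Compound 4 `CN(C)Cc1c(F)c(N)c2c(=O)cc(-c3ccc(N)c(F)c3)oc2c1F` differs from compound 3 in one place: (dimethylamino)methyl in place of ethoxycarbonyl on an aromatic carbon. Among the compounds with values here, no measured pair carries a (dimethylamino)methyl on that carbon, so the entering group itself is unanchored. What is anchored is the leaving group: both measured steps that introduced ethoxycarbonyl there raised the number greatly, and its removal is therefore expected to lower the number in this assay. The entering group is larger than methyl or amino and need not return the number all the way; the expected step is a 23-fold lower number from compound 3 to compound 4 (1.37 log units; beyond the scatter). Compound 4 is thus estimated at 60 nM, with a range of 10 nM to 400 nM.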

Compound 4, half-maximal inhibitory concentration: 72 nM
Estimate against measurement, compound 4: 1.2-fold (0.08 log units) below; the measured number falls inside the stated range.
By their numbers in this assay, from the lowest: compounds 2 and 1 (each within the scatter of the next); then compound 4; then compound 3.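

In this assay, the high number of compound 3 does not carry over to every substituent on this carbon larger than methyl or amino: (dimethylamino)methyl in place of ethoxycarbonyl gives a 19-fold lower number from compound 3 to compound 4 (1.29 log units; beyond the scatter). The carbon is still not indifferent to the change, since a 5.5-fold higher number from compound 1 to compound 4 (0.74 log units; beyond the scatter) and a 9.4-fold higher number from compound 2 to compound 4 (0.97 log units; beyond the scatter), whereas methyl and amino stay within the scatter of each other, so the cost of (dimethylamino)methyl is modest next to that of ethoxycarbonyl. No measurement shown here explains these differences.

Still open, as far as these compounds go, is whether the ester linkage, the carbonyl or the ethyl part drives the large rise, which a carboxylic acid or a primary amide on this carbon would help to separate. Equally open, from the compounds shown here alone, is whether the amine nitrogen matters, as a hydroxymethyl or a morpholinomethyl group could test.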